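The compounds below may be only part of what the source reports. "The series", "measured", "known", "first", "only" and "open" are said of these compounds alone.

In a functional assay on U-373MG ATCC cells (Homo sapiens) for inhibition, read by MTT assay, with a stated time of 72 h (a higher number here means a weaker inhibitor, a lower number a stronger inhibitor), compound 1 `CC1(C)CC(NC(=O)Nc2ccccc2Cl)c2cc(Cl)ccc2O1` gives 17000 nM. Compound 2 `CC(=O)NC1CC(C)(C)Oc2ccc(Cl)cc21` gives > 100000 nM, which is a limit and not a number. As far as these compounds go, compound 2 therefore sits at the limit of > 100000 nM in this assay, at which 1 of the 2 values shown sits, and how far its true value lies from that limit is unknown.

Compound 3 `CCNC(=O)NC1CC(C)(C)Oc2ccc(Cl)cc21` carries ethylamino in place of methyl on a carbonyl carbon. Among the measured compounds shown here, only one measured step bears on this change: an at least 5.8-fold higher number from compound 1 to compound 2 (0.76 log units; beyond the scatter), where methyl replaces (2-chlorophenyl)amino on a carbonyl carbon. That step is open-ended and is the reverse of the present kind of change, since compound 3 regains an amino group on the carbonyl carbon but has ethyl where compound 1 has 2-chlorophenyl. Only part of the size of that step is expected to return, so a modest move to a lower number in this assay is the likeliest outcome, and no visible move from the limit is also quite possible. The expected step is an at least 1.6-fold lower number from compound 2 to compound 3 (0.22 log units; that floor lies within the scatter). For compound 3 the estimated value is 60000 nM, with an expected range of 25000 nM to 100000 nM.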

Compound 3, half-maximal inhibitory concentration: > 100000 nM
Compound 3 gave a limit, no number; the forecaster's own chance of this, stated with the estimate: 50%; middle value at least 1.6-fold (0.22 log units) from the limit.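

In this assay compound 3 gives > 100000 nM, which is a limit and not a number. With ethyl in place of 2-chlorophenyl on an amide-type nitrogen, the series shows an at least 5.8-fold higher number from compound 1 to compound 3 (0.76 log units; beyond the scatter), so restoring an amino group on the carbonyl carbon is not enough on its own to bring back a readable value, and in this pair the readable value goes with the 2-chlorophenyl group. The step between compound 2 and compound 3 cannot be read, since both ends are limits and ethylamino in place of methyl on the carbonyl carbon therefore has no measurable size here: the limit of > 100000 nM in this assay, at which 2 of the 3 values shown sit.

As far as these compounds go, how far compound 2 and compound 3 lie from their limits stays open, and so does whether they differ from each other at all. Also open, from the compounds shown here alone, is which part of the 2-chlorophenyl group carries the difference, and whether an unsubstituted phenyl, a benzyl or a longer alkyl chain on that nitrogen would give a readable value.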